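Mirror-image question for a weakly cytotoxic compound

The compounds below may be only part of what the source reports. "The series", "measured", "known", "first", "only" and "open" are said of these compounds alone.

Going by the values given here, only two compounds have numbers so far. In a functional assay on HeLa cells (Homo sapiens) for cytotoxicity, read by MTT assay, with a stated time of 48 h (a higher number here means a weaker inhibitor, a lower number a stronger inhibitor), compound 1 `CCOC(=O)[C@@]1(C(=O)NCc2ccc(C)cc2)C[C@H]1c1cc(OC)c(OC)c(OC)c1` gives 19700 nM. In this assay, compound 2 `COc1cc([C@H]2C[C@]2(CO)C(=O)NCc2ccc(C)cc2)cc(OC)c1OC` gives 57800 nM, the higher of the two numbers, and its gap to compound 1 lies beyond the usual scatter of repeated measurements. Compound 2 is therefore the weaker inhibitor of this pair, and both numbers are large.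

The next compound is compound 3 `COc1cc([C@@H]2C[C@@]2(CO)C(=O)NCc2ccc(C)cc2)cc(OC)c1OC`, and the change from compound 2 is purely one of spatial arrangement: the two compounds have the same atoms and bonds and differ only in configuration as drawn: 2 of 2 stereo elements differ (all stereocentres are inverted: mirror images); a stereocentre at a saturated ring carbon is drawn R in compound 2 and S in compound 3; a stereocentre at a saturated ring carbon is drawn S in compound 2 and R in compound 3. Nothing leaves and nothing enters. Among the compounds with values here, a pair of mirror images can give matching or very different numbers in a cell assay, and no measured pair here shows which applies. With no such evidence, the expectation in this assay is a step no larger than the scatter, with only a weak lean towards a lower number. The estimated change is a 1.4-fold lower number from compound 2 to compound 3 (0.16 log units; within the scatter). Compound 3 is expected at about 40000 nM. The estimated range for compound 3 runs from 15000 nM to 110000 nM.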

Compound 3, half-maximal inhibitory concentration: 41200 nM
The estimate for compound 3 lay 1.0-fold (0.01 log units) below the measured number, and the stated range covers the measured number.
By their numbers in this assay, from the lowest: compound 1; then compounds 3 and 2 (each within the scatter of the next).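

In this assay, inverting both stereocentres gives a 1.4-fold lower number from compound 2 to compound 3 (0.15 log units; within the scatter), so this read-out does not separate the two mirror images, at least at these weak levels of cytotoxicity. Compound 3 also provides a second comparison at the saturated ring carbon, where hydroxymethyl in place of ethoxycarbonyl gives a 2.1-fold higher number from compound 1 to compound 3 (0.32 log units; beyond the scatter), a modest step beyond the scatter that matches the direction already seen with compound 2, so the choice of group at this carbon registers while the inversion does not. The mirror-image comparison is a clean reading of handedness alone because nothing else varies within the pair: the fact that compounds 2 and 3 differ only in the configuration as drawn

As far as these compounds go, it remains open whether the mirror image of compound 1 would also match its partner, and whether handedness would start to matter in a compound with a much lower number, since every value here is large. The compounds shown also leave open how a carboxylic acid, an amine or a longer chain at the same ring carbon would compare with hydroxymethyl and ethoxycarbonyl.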